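A few compounds are considered here, and "the series" means these few. Any claim that something is new, unique, unknown or untested is made for them only; others in the source may bear on it.

Compound 3 `COc1nc(N)c2nc(O)n(Cc3ccccc3)c2n1` is the reference point for this account. Among the compounds with values here, in a functional assay (spleen, spleen) for activation, with Mus musculus as the target (a higher number here means that more compound is needed for the effect, a lower number that less compound is needed), compound 3 gives 0.1 uM, the lowest of the three numbers so far. Compound 1 `CNc1nc(N)c2nc(O)n(Cc3ccccc3)c2n1` gives 1 uM in this assay, and compound 2 `CCCCNc1nc(N)c2nc(O)n(Cc3ccccc3)c2n1` gives 1 uM. The lengthening of the chain on the ring nitrogen, no change at the digits printed from compound 1 to compound 2 (within the scatter), left the readout untouched, whereas both a 10-fold lower number from compound 1 to compound 3 (1.00 log units; beyond the scatter) and a 10-fold lower number from compound 2 to compound 3 (1.00 log units; beyond the scatter) were brought about by exchanging the group on the same aromatic carbon of the shared core, the one that sits between two ring nitrogen atoms. Within the data shown here, that carbon is thus the one place where a change has so far moved the number beyond the scatter.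

Compound 4 `Nc1nc(S)nc2c1nc(O)n2Cc1ccccc1` differs from compound 3 at exactly that carbon: sulfanyl in place of methoxy on an aromatic carbon. The two informative steps bear directly on this position, and each was a modest step; they show the position responds to what sits on it, but neither involved a sulfanyl group, so the direction for compound 4 cannot be read from them. A modest shift in either sense is therefore plausible, and a small worsening is taken as the central expectation. For compound 4 the estimate is 0.3 uM, with a range from 0.03 uM to 3 uM. This estimate corresponds to an expected 3.0-fold higher number from compound 3 to compound 4 (0.48 log units; beyond the scatter).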

Compound 4, minimum effective concentration: 10 uM
For compound 4 the middle estimate is 33-fold (1.52 log units) below the measured one; the whole stated range lies below it.
By their numbers in this assay, from the lowest: compound 3; then compounds 1 and 2 (each within the scatter of the next); then compound 4.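

In this assay, within the data shown here, the change a 100-fold higher number from compound 3 to compound 4 (2.00 log units; beyond the scatter) is the largest step so far and shows that this carbon, between two ring nitrogen atoms, can move the number upward as well as downward, with the sulfanyl group giving the highest number of the four compounds. The two further steps, a 10-fold higher number from compound 1 to compound 4 (1.00 log units; beyond the scatter) and a 10-fold higher number from compound 2 to compound 4 (1.00 log units; beyond the scatter), place sulfanyl on the far side of both amino-linked groups from methoxy, so the order at this carbon runs from methoxy through methylamino and butylamino, which are within the scatter of each other, to sulfanyl. The change also shows that the outcome here depends on which atom or group is attached, since the methoxy and sulfanyl compounds stand at opposite ends of the series, but nothing available gives a measured reason for the higher number in compound 4.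

The compounds shown leave open whether the high number goes with the sulfur atom itself or with the hydrogen it carries, which a methylsulfanyl group at this carbon would separate. They also leave open whether a longer chain on the oxygen, such as ethoxy or butoxy, keeps the low number of compound 3 0.1 uM.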